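The source may hold more compounds than are shown below. What is called first, only, known or untested is meant among the compounds shown, and "the series" means these compounds.

Measured compounds:
Compound 1 `CC(=O)N1CCN(c2ccc(OCC3CCN(C(=O)OC(C)C)CC3)cn2)CC1` gives, in a functional assay on CHO-K1 cells for agonist activity at Glucose-dependent insulinotropic receptor (Homo sapiens), read by a luciferase reporter, with a stated time of 5 h (a higher number here means that more compound is needed for the effect, a lower number that less compound is needed), the limit > 10000 nM.
Compound 2 `CC(C)OC(=O)N1CCC(COc2ccc(N3CCN(C(=O)c4ccco4)CC3)nc2)CC1` gives 1900 nM.
Compound 3 `CCCS(=O)(=O)N1CCN(c2ccc(OCC3CCN(C(=O)CC(C)C)CC3)cn2)CC1` gives 1600 nM.

Compound 3 gives the lowest of the two numbers shown, but its nearest neighbour, compound 2, sits within the scatter of it, so the two cannot be told apart. Compound 1 reaches only a limit, which by itself says nothing more (the limit of > 10000 nM in this assay, at which 1 of the 3 values shown sits).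

Compound 4 `CCCS(=O)(=O)N1CCN(c2ccc(OCC3CCN(C(=O)NC4CCCCC4)CC3)cn2)CC1` differs from compound 3 in one place: cyclohexylamino in place of isobutyl on a carbonyl carbon. For the measured compounds named here, the only measured step that touches this carbonyl carbon is the one with a furan-2-yl in place of methyl, an at least 5.2-fold lower number from compound 1 to compound 2 (0.72 log units; beyond the scatter), where a larger group on that carbon went with a lower number, though on a core whose other end carried a different group. Compound 4 brings a larger, ring-bearing group onto the same carbonyl carbon, so a modest lowering in this assay is plausible, but with a single step of that kind behind it, a result within the scatter is also expected to be possible.

Compound 4 is therefore estimated at 1000 nM, within 300 nM to 4000 nM, which means an expected step of a 1.6-fold lower number from compound 3 to compound 4 (0.20 log units; within the scatter).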

Compound 4, half-maximal effective concentration: > 10000 nM
Compound 4 gave a limit, no number; the forecaster's own chance of this, stated with the estimate: 10%; at least 10-fold (1.00 log units) between middle value and limit.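

For the compounds shown here, on the carbonyl carbon bound to the amide-type ring nitrogen, replacing isobutyl with cyclohexylamino gives an at least 6.2-fold higher number from compound 3 to compound 4 (0.79 log units; beyond the scatter), whereas the only earlier step on such a carbon, on a differently substituted core, ran the other way: an at least 5.2-fold lower number from compound 1 to compound 2 (0.72 log units; beyond the scatter). A larger group on such a carbon therefore does not by itself go with a lower number in this assay: compound 2 fits that pattern, but compound 4 goes against it. Compound 4 gives only a limit, > 10000 nM, so the full size of its step remains unknown: the limit of > 10000 nM in this assay, at which 2 of the 4 values shown sit.

The change brings in a six-membered carbon ring, a nitrogen and a hydrogen-bond donor together, and these compounds do not show which of them goes with the higher number. Cyclohexylcarbonyl, which keeps the ring without the nitrogen, and isobutylamino, which keeps the nitrogen without the ring, would separate these features on the core of compound 3, and whether the step carries over to the core of compound 2 also remains open.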